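The source may hold more compounds than are shown below. What is called first, only, known or untested is meant among the compounds shown, and "the series" means these compounds.

Working notes on the series. Three compounds carry numbers in a functional assay on HeLa cells (Homo sapiens) for cytotoxicity, read by WST assay, with a stated time of 48 h; a lower number here means a stronger inhibitor, a higher number a weaker inhibitor. Compound 1 `COc1ccc(/C=C/C[C@H]2C[C@@H]([C@@H](O)c3ccccc3)CO[C@@H]2c2ccccc2)cc1` gives 8300 nM. Compound 2 `COc1ccc([C@H]2OC[C@H]([C@@H](O)c3ccc(OC)c(OC)c3)C[C@@H]2C/C=C/c2ccc(OC)c(OC)c2)cc1` gives 46700 nM, and compound 3 `COc1ccc(CCC[C@H]2C[C@@H]([C@@H](O)c3ccc(OC)c(OC)c3)CO[C@@H]2c2ccc(OC)c(OC)c2)cc1OC` gives 37700 nM. Compound 1 thus stands lowest of the three; its nearest neighbour is compound 3 and its furthest is compound 2, and both gaps lie beyond the usual scatter. For the measured compounds named here, no two of the measured compounds differ in one place only, so no single structural step has a measured size here.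

Compound 4 `O=[N+]([O-])c1cccc(/C=C/C[C@H]2C[C@@H]([C@@H](O)c3ccccc3)CO[C@@H]2c2ccccc2)c1` is not yet measured. It differs from compound 1 by 3-nitrophenyl in place of 4-methoxyphenyl on a double-bonded chain carbon bound to a double-bonded chain carbon. Going by the values given here, no measured pair in the set carries a comparable exchange, so the direction of the step rests on nothing better than the position of compound 1 alone. The expectation is a step from compound 1 to compound 4 that stays within the scatter, a 1.0-fold lower number from compound 1 to compound 4 (0.02 log units; within the scatter), with no strong pull either way. Compound 4 is therefore estimated at 8000 nM in this assay, with a range from 2500 nM to 25000 nM.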

Compound 4, half-maximal inhibitory concentration: 7850 nM
The estimate for compound 4 lay 1.0-fold (0.01 log units) above the measured number; measured number inside the range.
By their numbers in this assay, from the lowest: compounds 4 and 1 (each within the scatter of the next); then compounds 3 and 2 (each within the scatter of the next).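

In this assay, for the compounds shown here, 3-nitrophenyl in place of 4-methoxyphenyl on a double-bonded chain carbon bound to a double-bonded chain carbon gives the first measured step (a 1.1-fold lower number from compound 1 to compound 4 (0.02 log units; within the scatter)), and that step stays within the scatter. This place on the shared core therefore accepts a marked change of group, with one more heavy atom and one more hydrogen-bond acceptor, without a readable shift in the number. No measurement at hand bears on why the number holds.

From the compounds shown here alone, whether an amine, a carboxylic acid or a longer chain at this place would also leave the number unchanged remains open. Also open, going by these compounds, is whether the same exchange would keep its size on the more heavily methoxy-substituted frameworks of compound 2 and compound 3.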